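Oxan-4-yl in place of methyl on compound 2

The compounds below may be only part of what the source reports. "The series", "measured", "known", "first", "only" and "open" are said of these compounds alone.

In an ADME assay on LLC-PK1 cells (Sus scrofa) for permeability, read by LC-MS, with a stated time of 2 h, tested at 5 uM (on this read-out higher numbers stand for higher permeability and lower numbers for lower permeability), compound 2 (`Cc1cc2c(cn1)Oc1ccc(NC(=O)c3ccc(Cl)cn3)cc1[C@@]21COC(N)=N1`) gives 40 nm/s and stands highest of the three measured compounds, beyond the scatter of both others. Compound 3 (`CC1(C#Cc2cncc(-c3ccc4c(c3)[C@@]3(COC(N)=N3)c3cc(C5=CCOCC5)ncc3O4)c2)COC1`) gives 18 nm/s in this assay and compound 1 (`CC#Cc1cncc(-c2ccc3c(c2)[C@@]2(COC(N)=N2)c2cc(-c4ccnc(F)c4)ncc2O3)c1`) gives 15 nm/s there. Compound 4 (`NC1=N[C@@]2(CO1)c1cc(NC(=O)c3ccc(Cl)cn3)ccc1Oc1cnc(C3CCOCC3)cc12`) has oxan-4-yl in place of methyl on an aromatic carbon. Among the measured compounds shown here, no measured pair isolates such a change, so the guide is thin: the two compounds with larger groups on the shared core, compound 1 at 15 nm/s and compound 3 at 18 nm/s as well, both sit lower. A downward move is therefore expected, and a 1.8-fold lower number from compound 2 to compound 4 (0.26 log units; within the scatter) is the estimated step in this assay on this basis. For compound 4 the estimated value is 22 nm/s with an expected range from 10 nm/s to 45 nm/s in this measurement.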

Compound 4, apparent permeability: 27 nm/s
Beside the measured number, compound 4's estimate is 1.2-fold (0.09 log units) below it, within the range that was stated.
By their numbers in this assay, from the lowest: compounds 1, 3, 4 and 2 (each within the scatter of the next, the first and the last beyond it).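

At this aromatic carbon next to the ring nitrogen, oxan-4-yl in place of methyl gives (a 1.5-fold lower number from compound 2 to compound 4 (0.17 log units; within the scatter)) in this assay. Among the compounds shown here, this is the first step at this position that isolates a single change, and it shows that a six-membered non-aromatic ring with a hydrogen-bond acceptor can enter here with the read-out staying within the scatter. Nothing measured here explains the step.

The compounds shown leave open how a morpholin-4-yl group, a primary amine or a carboxylic acid on this carbon would read. They also leave open whether the same change would give a similar step with the other amide partners.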